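The source may hold more compounds than are shown below. What is called first, only, known or untested is meant among the compounds shown, and "the series" means these compounds.

Of the compounds shown here, three have so far been tested in a functional assay on Bel-7402 cells (Homo sapiens) for cytotoxicity, read by MTT assay; on this read-out lower numbers stand for stronger inhibition and higher numbers for weaker inhibition. Compound 1 `COc1cc(/C=C/C(=O)c2sc(Nc3ccccc3C)nc2C)cc(OC)c1OC` gives 10300 nM in this assay. Compound 2 `Cc1ccc(Nc2nc(C)c(C(=O)/C=C/c3ccc(Cl)cc3)s2)cc1` reaches only the limit of the measurement, > 25000 nM in this assay. Compound 3 `COc1cccc(/C=C/C(=O)c2sc(Nc3ccc(Cl)c(Cl)c3)nc2C)c1` likewise stops at the limit, > 25000 nM in this assay. Compound 2 therefore stands at the limit of > 25000 nM in this assay, at which 2 of the 3 values shown sit, and no number of its own is known for it.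

Compound 4 `Cc1nc(Nc2cccc(Cl)c2)sc1C(=O)/C=C/c1ccc(Cl)cc1` has not yet been measured. It differs from compound 2 in one place: 3-chlorophenyl in place of 4-methylphenyl on a nitrogen on an aromatic ring. Among the measured compounds shown here, no measured pair of compounds shows what this change does on its own, so the only guide is that compound 2 itself gave a limit rather than a number. A step of no size beyond the usual scatter is expected, and more likely than not compound 4 would again sit at the limit of this assay. The expected step is a step that the limit leaves unreadable from compound 2 to compound 4. Compound 4 is therefore estimated at 30000 nM in this assay, with a range from 12000 nM to 80000 nM, and with a real chance that only a limit and no number is reported.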

Compound 4, half-maximal inhibitory concentration: > 25000 nM
Compound 4: only a limit was reported; the forecaster's own chance of this, stated with the estimate: 70%; the middle value does not contradict the limit.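

Compound 2 and compound 4 both stop at a limit rather than a number, and no step can be read between them. The shared position of these compounds is this: the limit of > 25000 nM in this assay, at which 3 of the 4 values shown sit. The compounds shown leave open how far beyond the limit compound 2 and compound 4 lie, and whether 3-chlorophenyl in place of 4-methylphenyl changes anything.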